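The source may report more compounds than this note shows. Statements on the series, on what has been measured and on what is new or still open speak of the compounds shown alone.

In an in vitro functional assay on 1321-N1 cells for agonist activity at P2Y purinoceptor 6 (Homo sapiens), read by scintillation proximity assay and inositol phosphate accumulation (a lower number here means that less compound is needed, a higher number that more compound is needed for the effect), compound 1, `Nc1nc(=O)ccn1[C@@H]1O[C@H](COP(=O)(O)OP(=O)(O)O)[C@@H](O)[C@H]1O`, gives only a limit, >= 100000 nM. For the measured compounds named here, compound 2, `CSc1nc(=O)ccn1[C@@H]1O[C@H](COP(=O)(O)OP(=O)(O)O)[C@@H](O)[C@H]1O`, gives 4700 nM, the only number among the three values recorded here. Compound 3, `CCSc1nc(=O)ccn1[C@@H]1O[C@H](COP(=O)(O)O)[C@@H](O)[C@H]1O`, also gives only a limit in this assay, > 100000 nM. Going by the values given here, the one measured step in this assay, an at least 21-fold lower number from compound 1 to compound 2 (1.32 log units; beyond the scatter), is the sole reference point; the limits the limit of > 100000 nM in this assay, at which 1 of the 3 values shown sits, and the limit of >= 100000 nM in this assay, at which 1 of the 3 values shown sits, leave the true size of such steps open at the weak end. Among the compounds with values here, compound 3 differs from compound 2 in two places at once and so offers no single step to read.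

Compound 4, `CCCSc1nc(=O)ccn1[C@@H]1O[C@H](COP(=O)(O)OP(=O)(O)O)[C@@H](O)[C@H]1O`, differs from compound 2 by ethyl in place of hydrogen on a saturated chain carbon bound to a sulfur. Within the data shown here, no measured step concerns a change of this kind on the sulfur-bound chain; the only step in this assay altered the group on the aromatic carbon and is therefore no guide to the direction here. With compound 2 as the sole anchor, the expected step of a 1.3-fold lower number from compound 2 to compound 4 (0.13 log units; within the scatter) is taken as none beyond the scatter, with a wide margin left on either side. Compound 4 is therefore estimated at 3500 nM in this assay, within 500 nM to 40000 nM.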

Compound 4, half-maximal effective concentration: >= 100000 nM
Compound 4: only a limit was reported (the forecaster's own chance of this, stated with the estimate: 15%); middle value at least 28-fold (1.45 log units) from the limit.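

In this assay, the sulfur-bound chain proves sensitive to change: propylsulfanyl in place of methylsulfanyl gives an at least 21-fold higher number from compound 2 to compound 4 (1.32 log units; beyond the scatter), the only readable step at this chain among the compounds shown. The other readable step concerned the group on the aromatic carbon, an at least 21-fold lower number from compound 1 to compound 2 (1.32 log units; beyond the scatter), and the new step runs the opposite way, so the methylsulfanyl gain does not carry over to the longer propylsulfanyl chain. Compound 4 gives only a limit, >= 100000 nM, and the true size of the step stays open at the weak end: the limit of >= 100000 nM in this assay, at which 2 of the 4 values shown sit.

The step from compound 1 to compound 4 cannot be read, as both of its ends are limits. Going by these compounds, on the core of compound 2, it remains open whether an ethylsulfanyl group, a branched chain such as isopropylsulfanyl, or a chain ending in an amine or a carboxylic acid would give a measurable number, and so where along the chain the activity is lost.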